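This account rests on a few compounds, and the source may have more. Where it says the series, first, only, none or still open, it means among the compounds named here.

For the measured compounds named here, compound 1 `COc1ccc(-c2cc(/C=C/C(=O)c3ccc(N)cc3)[nH]n2)cc1` is one of three compounds measured so far. In a functional assay on HCC 2998 cells (Homo sapiens) for inhibition, read by sulforhodamine B assay, with a stated time of 48 h (a lower number here means that less compound is tolerated, a higher number that more compound is tolerated), compound 1 gives 6170 nM. The other two share the same linker but carry their groups in a different arrangement: compound 2 `COc1ccc(C(=O)/C=C/c2cc(-c3cc(OC)c(OC)c(OC)c3)n[nH]2)cc1OC` gives 6700 nM in this assay, and compound 3 `COc1ccc(C(=O)/C=C/c2cc(-c3cc(OC)c(OC)c(OC)c3)n[nH]2)cc1` gives 6480 nM. All three numbers lie within the usual scatter of one another, so none of them can be said to be tolerated better or worse than the rest. Going by the values given here, the single step between measured neighbours, a 1.0-fold lower number from compound 2 to compound 3 (0.01 log units; within the scatter), shows that taking away one methoxy group changed nothing that the assay could resolve.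

Compound 4 `COc1ccc(-c2cc(/C=C/C(=O)c3ccc(N)cc3)[nH]n2)cc1OC` has not yet been measured. It differs from compound 1 by methoxy in place of hydrogen on an aromatic carbon. Among the compounds with values here, this is the reverse of the only measured step, which was a 1.0-fold lower number from compound 2 to compound 3 (0.01 log units; within the scatter), so the expected step of a 1.0-fold higher number from compound 1 to compound 4 (0.02 log units; within the scatter) is none beyond the scatter. Compound 4 is therefore estimated to give 6400 nM in this assay, with a range from 3200 nM to 12800 nM.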

Compound 4, concentration lethal to 50% of the cells: 7240 nM
Compound 4: the middle estimate sits 1.1-fold (0.05 log units) below what was measured, and the stated range covers the measured number.
By their numbers in this assay, from the lowest: compounds 1, 3, 2 and 4 (each within the scatter of the next).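

Methoxy in place of hydrogen, on an aromatic carbon ortho to a methoxy group and meta to a large group, gives a 1.2-fold higher number from compound 1 to compound 4 (0.07 log units; within the scatter), which stays within the usual scatter. For the compounds shown here, the earlier compounds showed this change on only one core, so a lack of effect could have belonged to that core alone. It has now been seen on a second core, and this assay resolves it on neither, with the two steps agreeing: the same change on two cores in this assay, a 1.0-fold lower number (0.01 log units; within the scatter) from compound 2 to compound 3 and a 1.2-fold lower number (0.07 log units; within the scatter) from compound 4 to compound 1, 1.1-fold (0.05 log units) apart, within the scatter of two such steps

Only hydrogen and methoxy appear at this position in the compounds shown, so it remains open whether a very different group, such as a carboxylic acid or a longer chain like butoxy, would shift the number beyond the scatter. Going by these compounds, whether the same holds on other cell types also remains open.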